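One fluoro fewer on the 3,4-difluorophenyl group

This account rests on a few compounds, and the source may have more. Where it says the series, first, only, none or still open, it means among the compounds named here.

- Compound 1 `O=C(CCCN1CCCCCC1)Nc1cnc(-c2ccc(F)cc2F)s1` gives 2.11
- Compound 2 `O=C(CCCN1CCCCC1)Nc1cnc(-c2ccc(F)cc2)s1` gives 1.81
- Compound 3 `O=C(CCCN1CCCCCC1)Nc1cnc(-c2ccc(F)c(F)c2)s1` gives 2.3

These numbers come from a physicochemical assay for lipophilicity, read by LC-MS, measured as octanol-water partition, with a stated time of 18 h, at pH 7.4; a higher number here means a more lipophilic compound, a lower number a more polar compound. Compound 3 lies within the scatter of compound 1 and beyond the scatter over compound 2. Compound 4 `O=C(CCCN1CCCCCC1)Nc1cnc(-c2ccc(F)cc2)s1` has hydrogen in place of fluoro on an aromatic carbon, ortho to a fluoro group and meta to a large group (hydrogen in place of fluoro on an aromatic carbon). Within the data shown here, the one measured step on this ring moves a fluoro rather than removing it (a number 0.19 log units higher from compound 1 to compound 3 (within the scatter)), so it offers only indirect guidance. It suggests no large change. A small fall, not beyond the scatter, is expected (a number 0.15 log units lower from compound 3 to compound 4 (within the scatter)). Compound 4 is estimated at 2.15 (expected range 1.85 to 2.45).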

Compound 4, distribution coefficient: 1.93
Compound 4: middle estimate off by 0.22 log units, on the high side, and the stated range covers the measured number.
By their numbers in this assay, from the lowest: compounds 2, 4, 1 and 3 (each within the scatter of the next, the first and the last beyond it).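

In this assay, among these compounds, hydrogen in place of fluoro on the 3,4-difluorophenyl group gives a step beyond the scatter (a number 0.37 log units lower from compound 3 to compound 4 (beyond the scatter)), the first measured change on this ring to do so with the azepan-1-yl group held fixed. The same exchange on the 2,4-difluorophenyl group stays within the scatter (a number 0.18 log units lower from compound 1 to compound 4 (within the scatter)), as does azepan-1-yl in place of piperidin-1-yl (a number 0.12 log units higher from compound 2 to compound 4 (within the scatter)). Nothing here accounts for the difference between the two fluoro steps. As far as these compounds go, how a chloro or methoxy group at this carbon would read remains open, as does a morpholin-4-yl group on the chain.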